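The source may report more compounds than this note shows. Statements on the series, on what has been measured and on what is new or still open speak of the compounds shown alone.

Compound 1 `COc1cc(-c2ccnc3cc(-c4ccc(C)c(C)c4)nn23)cc(OC)c1OC` gives 272 nM in a functional assay on A549 cells (Homo sapiens) for inhibition, read by CCK-8 assay, with a stated time of 48 h; a higher number here means a weaker inhibitor, a lower number a stronger inhibitor. Among the three measured compounds it holds the second highest number; compound 2 `COc1cc(-c2ccnc3cc(-c4ccccc4)nn23)cc(OC)c1OC` gives 208 nM and compound 3 `COc1cc(-c2ccnc3cc(-c4ccc(N(C)C)cc4)nn23)cc(OC)c1OC` gives 1100 nM. Compound 4 `COc1cc(-c2ccnc3cc(-c4ccc(C(C)=O)cc4)nn23)cc(OC)c1OC` differs from compound 1 by 4-acetylphenyl in place of 3,4-dimethylphenyl on an aromatic carbon. For the measured compounds named here, two measured steps bear on this change: a 1.3-fold lower number from compound 1 to compound 2 (0.12 log units; within the scatter), whereas a 4.0-fold higher number from compound 1 to compound 3 (0.61 log units; beyond the scatter), and a 5.3-fold higher number from compound 2 to compound 3 (0.72 log units; beyond the scatter) points the same way. Going by the values given here, the 4-(dimethylamino)phenyl of compound 3 is thus the only measured change that moved the number beyond the scatter, toward weaker inhibition. For compound 4, which also carries a group on the phenyl, a smaller loss of the same kind is expected, a 1.5-fold higher number from compound 1 to compound 4 (0.19 log units; within the scatter). Compound 4 is estimated at 420 nM, with a range from 160 nM to 1100 nM.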

Compound 4, half-maximal inhibitory concentration: 4100 nM
Compound 4: the middle estimate sits 9.8-fold (0.99 log units) below what was measured; the measured number lies above the stated range.
By their numbers in this assay, from the lowest: compounds 2 and 1 (each within the scatter of the next); then compound 3; then compound 4.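

In this assay, for the compounds shown here, this position proves far less tolerant than the earlier compounds suggested, with a 15-fold higher number from compound 1 to compound 4 (1.18 log units; beyond the scatter) and a 20-fold higher number from compound 2 to compound 4 (1.29 log units; beyond the scatter) as the largest steps. The group on the phenyl matters as well as its presence, since a 3.7-fold higher number from compound 3 to compound 4 (0.57 log units; beyond the scatter) separates acetyl from dimethylamino, while the 3,4-dimethylphenyl of compound 1 goes against any rule that every added group costs inhibition. No measurement shown accounts for the loss from acetyl. Still open, going by these compounds, is how a primary amine, a carboxylic acid or a methyl ester on the phenyl would compare with acetyl.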